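The source may report more compounds than this note shows. Statements on the series, on what has been measured and on what is new or still open speak of the compounds shown alone.

Measured so far in a functional assay on the whole organism with Mus musculus as the target; on this read-out higher numbers stand for larger maximal responses and lower numbers for smaller maximal responses:
- compound 3 `Cn1c(=O)n(C2OC(CO)[C@@H](O)[C@H]2O)c2nc(N)nc(O)c21`: 100%
- compound 2 `CCCCCCn1c(=O)n(C2OC(CO)[C@@H](O)[C@H]2O)c2nc(N)nc(O)c21`: 11%
- compound 1 `Nc1nc(O)c2c(n1)n(C1OC(CO)[C@@H](O)[C@H]1O)c(=O)n2Cc1ccc(Cl)c(Cl)c1`: 0%

Compound 3 stands highest of the three, well beyond the scatter from both others; its nearest is compound 2, separated by the step of a number 89 percentage points higher from compound 2 to compound 3 (beyond the scatter), and compound 1 lies furthest, separated by a number 100 percentage points higher from compound 1 to compound 3 (beyond the scatter). Compound 4 `CCCCn1c(=O)n(C2OC(CO)[C@@H](O)[C@H]2O)c2nc(N)nc(O)c21` differs from compound 3 by propyl in place of hydrogen on a saturated chain carbon bound to an aromatic nitrogen. Among the measured compounds shown here, the step that bears on this is the one from compound 2 to compound 3, where hydrogen replaced pentyl at the same place and the number rose by a number 89 percentage points higher from compound 2 to compound 3 (beyond the scatter). Going the other way, adding a shorter chain, a drop is therefore expected for compound 4, though perhaps less deep than with pentyl: a number 65 percentage points lower from compound 3 to compound 4 (beyond the scatter). Compound 4 is estimated at 35%, between 10% and 75%.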

Compound 4, largest response reached (reported as maximal response), in percent of the reference or control that the assay uses: 70%
Compound 4: middle estimate off by 35 percentage points, on the low side, and the stated range covers the measured number.
By their numbers in this assay, from the lowest: compound 1; then compound 2; then compound 4; then compound 3.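

In this assay, propyl in place of hydrogen on this saturated chain carbon costs only part of the response, a number 30 percentage points lower from compound 3 to compound 4 (beyond the scatter), while removing ethyl from the end of the longer chain gives a number 59 percentage points higher from compound 2 to compound 4 (beyond the scatter), so among compounds 3, 4 and 2 the response falls as the chain grows, and most of the loss comes after propyl. Propyl also keeps far more response than 3,4-dichlorophenyl at this place, a number 70 percentage points higher from compound 1 to compound 4 (beyond the scatter). Nothing measured here explains why the response falls with size. Going by these compounds, how an ethyl chain, or a chain ending in an amine or a carboxylic acid, would behave at this place remains open.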